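A few compounds are considered here, and "the series" means these few. Any claim that something is new, unique, unknown or untested is made for them only; others in the source may bear on it.

Compound 1 `FC(F)(F)c1cccc(-c2nc3cnc(Nc4ncccn4)cc3[nH]2)c1` — in a physicochemical assay for solubility, using the shake flask method, measured as kinetic solubility, with a stated time of 20 h, at pH 2 (a lower number here means a less soluble compound, a higher number a more soluble compound), compound 1 gives 155000 nM.
Compound 2 `Fc1ccc(Nc2cc3[nH]c(-c4cccc(C(F)(F)F)c4)nc3cn2)nc1` — in this assay compound 2 gives only a limit of the assay, < 5000 nM.

Among the compounds with values here, the single measured step, an at least 31-fold lower number from compound 1 to compound 2 (1.49 log units; beyond the scatter), places compound 2 at the lower end of the two values, known only as a limit (the limit of < 5000 nM in this assay, at which 1 of the 2 values shown sits). Compound 3 `O=C(O)c1ccnc(Nc2cc3[nH]c(-c4cccc(C(F)(F)F)c4)nc3cn2)c1` differs from compound 2 by 4-carboxypyridin-2-yl in place of 5-fluoropyridin-2-yl on a nitrogen on an aromatic ring. Within the data shown here, no measured step covers this exchange, so the earlier step gives no direction for it. For compound 3 a modest rise above the limit is expected, an at least 1.6-fold higher number from compound 2 to compound 3 (0.20 log units; that floor lies within the scatter), though another limit read-out is possible. Compound 3 is estimated at 8000 nM, range 2000 nM to 40000 nM.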

Compound 3, solubility: < 5000 nM
Compound 3 was reported as a limit; the forecaster's own chance of this, stated with the estimate: 40%; at least 1.6-fold (0.20 log units) between middle value and limit.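

In this assay, 4-carboxypyridin-2-yl in place of pyrimidin-2-yl on the nitrogen gives an at least 31-fold lower number from compound 1 to compound 3 (1.49 log units; beyond the scatter), so the fall seen with 5-fluoropyridin-2-yl is not confined to that one group. The step between compound 2 and compound 3 cannot be read, as both values are limits. Two differently substituted pyridin-2-yl groups now end at the same limit: the limit of < 5000 nM in this assay, at which 2 of the 3 values shown sit.

As far as these compounds go, how far compound 2 and compound 3 actually lie from that limit stays open. Also open, from the compounds shown here alone, is whether an amine on the pyrimidin-2-yl ring would keep the read-out near that of compound 1.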